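The compounds below may be only part of what the source reports. "The series", "measured", "known", "first", "only" and "open" are said of these compounds alone.

Compound 1 `COCOc1cc(/C=C/C(=O)OCC(=O)Nc2ccc(OC)cc2)ccc1OCc1ccccc1`: in a functional assay on LS174T cells (Homo sapiens) for cytotoxicity, read by MTT assay, with a stated time of 72 h (a lower number here means a stronger inhibitor, a higher number a weaker inhibitor), compound 1 gives > 200000 nM, which is a limit of the assay and not a number.
Compound 2 `CCOc1ccc(COc2c(OC)cc(/C=C/C(=O)OCC(=O)Nc3ccccc3)cc2OC)cc1`: in this assay compound 2 gives > 200000 nM, again a limit of the assay rather than a number.

Compound 2 thus stands at the edge of what this assay can report, and both values shown sit at that same limit (the limit of > 200000 nM in this assay, at which 2 of the 2 values shown sit). Compound 3, `CCOc1ccc(COc2c(OC)cc(/C=C/C(=O)OCC(=O)Nc3ccc(Cl)cc3)cc2OC)cc1`, differs from compound 2 in a single place: chloro in place of hydrogen on an aromatic carbon, a chloro in place of hydrogen on an aromatic carbon, para to a large group. Among the compounds with values here, no step between two measured compounds is available to gauge what such a change does; the two measured values show only that neither compound reaches the range the assay resolves. For the step from compound 2 to compound 3 in this assay, no move beyond the scatter is expected, a number no higher from compound 2 to compound 3 (the limit leaves the size open), and the most likely outcome is once more a limit instead of a number. Compound 3 is therefore expected near 200000 nM, in the range 50000 nM to 600000 nM.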

Compound 3, half-maximal inhibitory concentration: > 200000 nM
Compound 3: only a limit was reported; the forecaster's own chance of this, stated with the estimate: 80%; the middle value sits exactly at the limit.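

Within the data shown here, compound 2 and compound 3 both give only a limit and not a number, so no step for chloro in place of hydrogen can be read between them: the limit of > 200000 nM in this assay, at which 3 of the 3 values shown sit.
The compounds shown leave open which change to the shared core, if any, would give a measurable value in this assay.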